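Swapping Chloro for Bromo at the Aromatic Carbon

The source may hold more compounds than are shown below. What is called first, only, known or untested is meant among the compounds shown, and "the series" means these compounds.

Compound 2 `Clc1ccc([C@H]2CC(c3ccccc3)=NN2c2ncc(Br)cn2)cc1` was tested in a functional assay on the whole organism (strain Wistar albino) for inhibition, with Rattus norvegicus as the target, read by paw edema, with stated times of 30 min and 1 h, at a dose of 20 mg/kg (on this read-out lower numbers stand for less inhibition and higher numbers for more inhibition at the one dose given (going by the name of the read-out)), where compound 2 gives 70%. Going by the values given here, that is the higher of the two numbers measured so far, yet compound 1 `Cc1ccc([C@H]2CC(c3ccccc3)=NN2c2ncc(Br)cn2)cc1` gives 68% in this assay, and the step of a number 2 percentage points higher from compound 1 to compound 2 (within the scatter) lies within the scatter, so the two compounds cannot be told apart. The change to compound 3 `Brc1ccc([C@H]2CC(c3ccccc3)=NN2c2ncc(Br)cn2)cc1` is bromo in place of chloro on an aromatic carbon. Among the compounds with values here, the only measured step that bears on it is the earlier exchange at the same aromatic carbon, chloro in place of methyl, which moved the read-out by a number 2 percentage points higher from compound 1 to compound 2 (within the scatter). That exchange left the number essentially unmoved, and a second exchange of one heavy atom for another at the same place is expected to do the same. Compound 3 is therefore expected to show a step of no change at the digits printed from compound 2 to compound 3 (within the scatter) in this assay. Compound 3 is estimated at 70%, with a range from 60% to 80%.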

Compound 3, a percentage reported as inhibition, in the whole organism at one dose (the size of the read-out at that dose, not a potency): 68%
Compound 3: middle estimate off by 2 percentage points, on the high side, and the stated range covers the measured number.
By their numbers in this assay, from the lowest: compounds 1, 3 and 2 (each within the scatter of the next).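

In this assay, bromo in place of chloro on this aromatic carbon gives a number 2 percentage points lower from compound 2 to compound 3 (within the scatter) and bromo in place of methyl gives no change at the digits printed from compound 1 to compound 3 (within the scatter) in the same read-out. With a third group now in hand and the two halogens compared directly, methyl, chloro and bromo at this place on the shared core cannot be told apart, so all three exchanges among them fall within the scatter. Nothing in the available data explains why these three groups read alike.

From the compounds shown here alone, whether a group of a different kind on this aromatic carbon, such as an amine, a carboxylic acid or a longer chain, would stay in the same range remains open. Also open, going by these compounds, is whether the 4-chlorophenyl and 4-bromophenyl compounds would still read alike at another dose.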